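The source may hold more compounds than are shown below. What is called first, only, known or untested is meant among the compounds shown, and "the series" means these compounds.

Working notes on the sulfonyl hydrazide series. In a functional assay on PC-3 cells (Homo sapiens) for antiproliferative activity (on this read-out higher numbers stand for weaker inhibition of growth and lower numbers for stronger inhibition of growth), compound 1 `CC(=O)Nc1ccc(S(=O)(=O)NNC(=O)c2cccnc2Nc2ccc(Cl)cc2)cc1` reports only a limit of the assay, > 100000 nM, so it stands at the limit of > 100000 nM in this assay, at which 1 of the 2 values shown sits, and its place on the scale is not fixed by a number. Among the compounds with values here, compound 2 `O=C(NNS(=O)(=O)c1ccc(F)cc1)c1cccnc1Nc1ccc(Cl)cc1Cl`, which carries a 4-fluorophenyl on the sulfonyl and a second chlorine on the anilino ring, gives 32400 nM in this assay and is the only member with a measured number. Compound 3 `O=C(NNS(=O)(=O)c1ccc(Cl)cc1Cl)c1cccnc1Nc1ccc(Cl)cc1` is the next member to be run. It differs from compound 1 in one place: 2,4-dichlorophenyl in place of 4-acetamidophenyl on a sulfonyl sulfur. Within the data shown here, no measured pair carries this exchange, so the size of the step is open; the expectation is that it moves toward stronger inhibition of growth, as the step from compound 1 to compound 3 is estimated at an at least 2.5-fold lower number from compound 1 to compound 3 (0.39 log units; beyond the scatter) in this assay. For compound 3 the estimate in this assay is 40000 nM, with a range from 10000 nM to 150000 nM.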

Compound 3, concentration for total growth inhibition: 81300 nM
Compound 3: middle estimate off by 2.0-fold (0.31 log units), on the low side, within the range that was stated.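

In this assay, 2,4-dichlorophenyl in place of 4-acetamidophenyl on the sulfonyl sulfur gives an at least 1.2-fold lower number from compound 1 to compound 3 (0.08 log units; that floor lies within the scatter). Compound 1 is only a limit of the assay, so this step has a floor and no fixed size: the limit of > 100000 nM in this assay, at which 1 of the 3 values shown sits. What is new is that compound 3, with 2,4-dichlorophenyl at this place, reads as a number on the scale, 81300 nM, and so gives the series a measured value for a group with no hydrogen-bond donors or acceptors on the sulfonyl sulfur.

The compounds shown leave open whether the loss of the acetamido group or the entry of the two chlorines carries the step, as the exchange changes both at once. From the compounds shown here alone, how a 4-aminophenyl or a 4-carboxyphenyl on the sulfonyl sulfur of the same core would read also stays open.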